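The compounds below may be only part of what the source reports. "The series", "measured", "known", "first", "only" and "open" are said of these compounds alone.

Measured in an ADME assay on A549 cells (Homo sapiens) for cytotoxicity, read by resazurin assay, with a stated time of 48 h; on this read-out lower numbers stand for higher toxicity in this test and higher numbers for lower toxicity in this test:
- Compound 1 (`CCCCCCC(C)Nc1ccc(NC(=O)c2cc(Cl)ccc2O)c(Cl)c1`) gives 23500 nM
- Compound 2 (`O=C(Nc1ccc(NCc2cccnc2Cl)cc1Cl)c1cc(Cl)ccc1O`) gives 101000 nM

Among the compounds with values here, compound 2 stands higher of the two, at 101000 nM, the top of the numbers so far. Compound 3 (`O=C(Nc1ccc(NCc2ccc(Br)s2)cc1Cl)c1cc(Cl)ccc1O`) carries 5-bromothiophen-2-yl in place of 2-chloropyridin-3-yl on a saturated chain carbon bound to a nitrogen on an aromatic ring. Within the data shown here, only one measured step bears on this, at the same nitrogen but for a different exchange: a 4.3-fold higher number from compound 1 to compound 2 (0.63 log units; beyond the scatter). It is modest and guides the size only loosely. A smaller step towards a lower number is therefore expected in this assay, and the direction is uncertain. The estimated step is a 2.2-fold lower number from compound 2 to compound 3 (0.35 log units; beyond the scatter). For compound 3 the estimated value is 45000 nM, with an expected range of 16000 nM to 120000 nM.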

Compound 3, half-maximal cytotoxic concentration: 20700 nM
For compound 3 the middle estimate is 2.2-fold (0.34 log units) above the measured one; the range from low to high includes it.
By their numbers in this assay, from the lowest: compounds 3 and 1 (each within the scatter of the next); then compound 2.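

In this assay the group on the saturated chain carbon bound to a nitrogen on an aromatic ring clearly matters: 5-bromothiophen-2-yl in place of 2-chloropyridin-3-yl gives a 4.9-fold lower number from compound 2 to compound 3 (0.69 log units; beyond the scatter) and so cancels the rise that compound 2 showed. Not every aromatic replacement for 1-methylheptyl therefore behaves alike, and (5-bromothiophen-2-yl)methyl gives a 1.1-fold lower number from compound 1 to compound 3 (0.06 log units; within the scatter) with no real separation from that chain. Nothing at hand explains the gap between the two rings.

Going by these compounds, the ring and its halogen change together here, so which of them carries the step stays open. A plain phenyl group at this place would help to separate them.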